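This account rests on a few compounds, and the source may have more. Where it says the series, first, only, none or still open, it means among the compounds named here.

Measured compounds in an ADME assay on HepG2 2.2.15 cells (Homo sapiens) for cytotoxicity, read by MTT assay, with stated times of 48 h and 9 days; a lower number here means that less compound is tolerated, a higher number that more compound is tolerated: compound 1 `COc1ccc2c(=O)c(/C=C/C(=O)Nc3ccc(C)cc3)coc2c1` gives 979000 nM; compound 2 `COc1ccc2c(=O)c(/C=C/C(=O)NCc3ccccc3)coc2c1` gives 376000 nM; compound 3 `COc1cccc(NC(=O)/C=C/c2coc3cc(OC)ccc3c2=O)c1` gives 1130000 nM.

Among these three numbers, compound 1 stands second highest. Its nearest neighbour is compound 3, separated by a 1.2-fold higher number from compound 1 to compound 3 (0.06 log units; within the scatter), a gap within the scatter. Among the compounds with values here, its furthest is compound 2, reached through a 2.6-fold lower number from compound 1 to compound 2 (0.42 log units; beyond the scatter), the only change from compound 1 that moves the number beyond the scatter. Compound 4 `COc1ccc2c(=O)c(/C=C/C(=O)Nc3ccccc3C)coc2c1` differs from compound 1 at the amide-type nitrogen: 2-methylphenyl in place of 4-methylphenyl on an amide-type nitrogen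

Within the data shown here, two measured steps bear on this. The exchange of one aromatic ring for another on the same nitrogen, a 1.2-fold higher number from compound 1 to compound 3 (0.06 log units; within the scatter), stayed within the scatter. Only the move to benzyl, a 2.6-fold lower number from compound 1 to compound 2 (0.42 log units; beyond the scatter), gave a modest step, and that change is of a different kind. The swap of 4-methylphenyl for 2-methylphenyl keeps the same atoms and the same ring, so no step beyond the scatter is expected in this assay.

Compound 4 is therefore expected to give about 950000 nM, within 450000 nM to 2000000 nM, which means an expected step of a 1.0-fold lower number from compound 1 to compound 4 (0.01 log units; within the scatter).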

Compound 4, half-maximal cytotoxic concentration: 59700 nM
Compound 4: middle estimate off by 16-fold (1.20 log units), on the high side; the whole stated range lies above it.
By their numbers in this assay, from the lowest: compound 4; then compound 2; then compounds 1 and 3 (each within the scatter of the next).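

In this assay the methyl group changing place on the ring, with the same atoms throughout, gave a 16-fold lower number from compound 1 to compound 4 (1.21 log units; beyond the scatter) and so showed that this position on the amide-type nitrogen can respond strongly to an isomeric change, which the exchange of compound 1 for compound 3 had not revealed. Against the other two compounds the drop persists, with a 19-fold lower number from compound 3 to compound 4 (1.28 log units; beyond the scatter) and a 6.3-fold lower number from compound 2 to compound 4 (0.80 log units; beyond the scatter) placing compound 4 lowest of the four, so here less of it is tolerated than of any other compound shown. Nothing available here accounts for this drop.

The compounds shown leave open whether the low number belongs to the methyl group itself or would recur with 2-methoxyphenyl or 2-chlorophenyl in its place. They also leave open where 3-methylphenyl would fall relative to compound 1 and compound 4.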